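The compounds below may be only part of what the source reports. "The series", "measured", "known", "first", "only" and "open" are said of these compounds alone.

Among the compounds with values here, compound 2 `CCCN(CCC)c1nc(-c2ccc(Cl)cc2Cl)n(C)n1` is the one member of the series with a number rather than a limit in an assay on CHO cells for binding affinity to corticotropin-releasing factor receptor 1 (Homo sapiens); on this read-out higher numbers stand for weaker inhibition and lower numbers for stronger inhibition: in this assay compound 2 gives 2600 nM. Compound 1 `CCCN(CC1CC1)c1nc(-c2ccc(Cl)cc2Cl)n(C)n1` reaches only the assay limit, > 10000 nM, in this assay, a limit and not a number (the limit of > 10000 nM in this assay, at which 1 of the 2 values shown sits). Within the data shown here, the step of an at least 3.8-fold lower number from compound 1 to compound 2 (0.58 log units; beyond the scatter) is the single measured change, an ethyl in place of cyclopropyl on the saturated chain carbon bound to the ring nitrogen.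

Compound 3 `CCCN(CCC)c1nc(-c2ccc(Cl)cc2Cl)n(CCO)n1` differs from compound 2 at another site: hydroxymethyl in place of hydrogen on a saturated chain carbon bound to an aromatic nitrogen. Among the measured compounds shown here, no measured step touches this part of the molecule, so the step from compound 1 to compound 2 gives no direct guide to its size or direction. With nothing against it, the step of no change at the digits printed from compound 2 to compound 3 (within the scatter) is expected to stay within the scatter. For compound 3 the estimate in this assay is 2600 nM, with a range from 900 nM to 7500 nM.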

Compound 3, inhibition constant: 14 nM
For compound 3 the middle estimate is 190-fold (2.27 log units) above the measured one; measured number outside the range, below it.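

Hydroxymethyl in place of hydrogen on a saturated chain carbon bound to an aromatic nitrogen gives a 190-fold lower number from compound 2 to compound 3 (2.27 log units; beyond the scatter) in this assay, so this position, which the earlier pair left untouched, accepts a larger group than methyl and strongly changes the read-out. The earlier step, an at least 3.8-fold lower number from compound 1 to compound 2 (0.58 log units; beyond the scatter), lies at another site and starts from an assay limit, so the two step sizes cannot be ranked. Nothing shown accounts for the size of the new step.

Going by these compounds, whether the gain needs the hydroxyl or only the longer chain remains open; an ethyl, a propyl or a 2-methoxyethyl group at this position would separate the two. Also open, on these data alone, is whether the gain carries over when the cyclopropyl-bearing chain of compound 1 replaces a propyl chain.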